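The source may hold more compounds than are shown below. What is called first, only, known or untested is meant among the compounds shown, and "the series" means these compounds.

Of the compounds shown here, two have so far been measured in an ADME assay on MRC5 cells (Homo sapiens), read by MTT assay, with a stated time of 72 h; a lower number here means a stronger inhibitor, a higher number a weaker inhibitor. Compound 1, `C#Cc1cn([C@@H]2O[C@H](CO)[C@@H](O)[C@H]2O)c2ncnc(OC)c12`, carries a methoxy on its core; in this assay compound 1 gives > 100000 nM, which is a limit of the assay rather than a number. Compound 2, `Cc1ncnc2c1c(-c1cccs1)cn2[C@@H]1O[C@H](CO)[C@@H](O)[C@H]1O`, gives > 100000 nM in this assay, again only a limit and not a number. Compound 2 therefore sits at the limit of > 100000 nM in this assay, at which 2 of the 2 values shown sit, so nothing in the present data separates the two compounds.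

Compound 3, `COc1ncnc2c1c(-c1cccs1)cn2[C@@H]1O[C@H](CO)[C@@H](O)[C@H]1O`, differs from compound 2 in one place: methoxy in place of methyl on an aromatic carbon. Within the data shown here, no step between measured compounds is available to calibrate this change, and both values shown are limits. The step of a number no higher from compound 2 to compound 3 (the limit leaves the size open) is therefore expected to be none beyond the scatter, in no clear direction. Compound 3 is accordingly estimated at 100000 nM, with a likely range from 40000 nM to 250000 nM, and most probably the assay will once more report only a limit.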

Compound 3, half-maximal inhibitory concentration: 43200 nM
For compound 3 the middle estimate is 2.3-fold (0.36 log units) above the measured one; the range from low to high includes it.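

In this assay, methoxy in place of methyl on the aromatic carbon next to the ring nitrogen gives an at least 2.3-fold lower number from compound 2 to compound 3 (0.36 log units; beyond the scatter), so, with thiophen-2-yl held in place, this position responds to the change. With methoxy held in place, thiophen-2-yl in place of ethynyl on an aromatic carbon gives an at least 2.3-fold lower number from compound 1 to compound 3 (0.36 log units; beyond the scatter), so the second group matters as well. Of the compounds shown, only compound 3, which pairs methoxy with thiophen-2-yl, gives a number rather than a limit: the limit of > 100000 nM in this assay, at which 2 of the 3 values shown sit.

As far as these compounds go, both steps start from a limit, so their full size remains unknown. The compounds shown also leave open whether an amine or a longer chain such as ethoxy at this position would lower the number further, and whether a phenyl ring could take the place of thiophen-2-yl.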